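The compounds below may be only part of what the source reports. "The series", "measured", "known", "first", "only" and "open" are said of these compounds alone.

Compound 1 `CCCCCNc1nc(N)c2nc(O)n(Cc3ccccc3)c2n1` gives the lowest number of the three measured compounds in a functional assay on the whole organism for activation, with Mus musculus as the target (a higher number here means that more compound is needed for the effect, a lower number that less compound is needed), with 0.3 mg/kg. Compound 2 `CCc1nc(N)c2nc(O)n(Cc3ccccc3)c2n1` gives 3 mg/kg, and compound 3 `CCCC[S+]([O-])c1nc(N)c2nc(O)n(Cc3ccccc3)c2n1` gives 1 mg/kg. Compound 4 `CCOc1nc(N)c2nc(O)n(Cc3ccccc3)c2n1` differs from compound 1 in one place: ethoxy in place of pentylamino on an aromatic carbon. Among the measured compounds shown here, two measured steps bear on this change. Replacing pentylamino with ethyl gave a 10-fold higher number from compound 1 to compound 2 (1.00 log units; beyond the scatter), and replacing it with a group of 6 heavy atoms (4 carbon, 1 oxygen, 1 sulfur; no ring) gave a 3.3-fold higher number from compound 1 to compound 3 (0.52 log units; beyond the scatter). Both point the same way: removing pentylamino raised the number beyond the scatter. Ethoxy resembles ethyl more than it resembles pentylamino, so a step of the same kind is expected, a 6.7-fold higher number from compound 1 to compound 4 (0.82 log units; beyond the scatter). Compound 4 is therefore estimated to need 2 mg/kg in this assay, within a range from 0.6 mg/kg to 6 mg/kg.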

Compound 4, minimum effective dose: 0.3 mg/kg
The estimate for compound 4 lay 6.7-fold (0.82 log units) above the measured number, and the stated range ends above it.
By their numbers in this assay, from the lowest: compounds 1 and 4 (each within the scatter of the next); then compound 3; then compound 2.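

In this assay, ethoxy on this carbon between two ring nitrogen atoms gives no change at the digits printed from compound 1 to compound 4 (within the scatter), so neither the pentylamino chain's length nor its hydrogen-bond donor is required for the low number. Ethoxy in place of ethyl gives a 10-fold lower number from compound 2 to compound 4 (1.00 log units; beyond the scatter), showing that a short group can match pentylamino only in some forms, while the change from the sulfur-bearing group gives a 3.3-fold lower number from compound 3 to compound 4 (0.52 log units; beyond the scatter). Nothing available explains these differences. As far as these compounds go, it remains open how the number depends on chain length with oxygen attached at this carbon, as pentyloxy would show. Ethylamino would show whether a short chain attached through nitrogen behaves like ethoxy.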